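This account rests on a few compounds, and the source may have more. Where it says the series, first, only, none or still open, it means among the compounds named here.

Measured compounds:
compound 1 `CCOC(=O)/C=C/c1ccc(OC)cc1OC(=O)c1nc(C)c(C)nc1C`: -57.6%
compound 2 `CCOC(=O)/C=C/c1ccc(OC(=O)c2nc(C)c(C)nc2C)c(O)c1`: 75.7%

In a functional assay on EA.hy 926 cells (Homo sapiens) for cytotoxicity, read by MTT assay, with stated times of 24 h and 12 h, tested at 12.5 uM (on this read-out lower numbers stand for a weaker effect and higher numbers for a stronger effect at the one concentration tested), compound 1 gives -57.6%, while compound 2 gives 75.7%. Compound 2 stands highest of the two numbers; compound 1 sits far below it, a gap well beyond the usual scatter. Compound 3 `CCOC(=O)/C=C/c1ccc(OC(=O)c2nc(C)c(C)nc2C)cc1` is the next compound to be measured. Its difference from compound 2 is hydrogen in place of hydroxy on an aromatic carbon. For the measured compounds named here, no step between two measured compounds that differ in only one place is available, so the size of this change has to be judged from the two values alone. The step of a number 45.7 percentage points lower from compound 2 to compound 3 (beyond the scatter) is expected to be downward and of moderate size, beyond the scatter, but not reaching the low number of compound 1. Compound 3 is estimated at 30%, with a range from -20% to 70%.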

Compound 3, a percentage reported as activity, at one concentration (the size of the read-out at that concentration, not a potency): 42.7%
Beside the measured number, compound 3's estimate is 12.7 percentage points below it; the range from low to high includes it.
By their numbers in this assay, from the lowest: compound 1; then compound 3; then compound 2.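

For the compounds shown here, this pair gives the first comparison in which only one place changes. In this assay, putting hydrogen in place of hydroxy on the aromatic carbon ortho to a large group comes with a number 33 percentage points lower from compound 2 to compound 3 (beyond the scatter), so the read-out depends clearly on what stands at this position. The hydroxy is not needed for a positive reading, however, since compound 3 still gives 42.7% in this assay, and nothing available explains the size of the step.

The compounds shown leave open whether an amine or a fluorine on this carbon would give a reading nearer to that of compound 2 or of compound 3. They also leave open whether the step would keep its size if a carboxylic acid replaced the ester of the 2-(ethoxycarbonyl)ethenyl group.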